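Benzyl-type ethers in place of the allyl ether

A few compounds are considered here, and "the series" means these few. Any claim that something is new, unique, unknown or untested is made for them only; others in the source may bear on it.

compound 1 `C=CCOc1cc(/C=C\c2cc(OC)c(OC)c(OC)c2)ccc1OC` gives 43500 nM
compound 2 `COc1ccc(/C=C\c2cc(OC)c(OC)c(OC)c2)cc1OCc1ccccc1` gives 15000 nM
compound 3 `COc1ccc(COc2cc(/C=C\c3cc(OC)c(OC)c(OC)c3)ccc2OC)cc1` gives 64000 nM

In an ADME assay on HEK293 cells (Homo sapiens) for inhibition, read by MTT assay, with a stated time of 3 days (on this read-out higher numbers stand for weaker inhibition and lower numbers for stronger inhibition), compound 1 at 43500 nM stands second highest of the three numbers. Going to compound 4 `COc1ccc(/C=C\c2cc(OC)c(OC)c(OC)c2)cc1OCc1ccc(Br)cc1` brings 4-bromophenyl in place of vinyl on a saturated chain carbon bound to an oxygen on an aromatic ring with 4-bromophenyl in place of vinyl on a saturated chain carbon bound to an oxygen on an aromatic ring. Within the data shown here, two measured steps bear on this: a 2.9-fold lower number from compound 1 to compound 2 (0.46 log units; beyond the scatter) with phenyl, and a 1.5-fold higher number from compound 1 to compound 3 (0.17 log units; within the scatter) with 4-methoxyphenyl. The ring substituent also counts, as a 4.3-fold higher number from compound 2 to compound 3 (0.63 log units; beyond the scatter) shows. Among the measured compounds shown here, no bromo compound has been measured, so a position between these outcomes is assumed. The expected step is a 1.5-fold lower number from compound 1 to compound 4 (0.16 log units; within the scatter) and no change beyond the scatter is expected. Compound 4 is estimated at 30000 nM with an expected range from 12000 nM to 75000 nM as the working figure.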

Compound 4, half-maximal inhibitory concentration: 45000 nM
For compound 4 the middle estimate is 1.5-fold (0.18 log units) below the measured one, within the range that was stated.
By their numbers in this assay, from the lowest: compound 2; then compounds 1, 4 and 3 (each within the scatter of the next).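

Bromo in place of hydrogen on an aromatic carbon gives a step in the same direction as methoxy (a 3.0-fold higher number from compound 2 to compound 4 (0.48 log units; beyond the scatter)). Compound 2 thus stands apart from compounds 1, 3 and 4, as the 4-bromophenyl group shows no change beyond the scatter against vinyl (a 1.0-fold higher number from compound 1 to compound 4 (0.01 log units; within the scatter)) or against 4-methoxyphenyl with bromo in place of methoxy (a 1.4-fold lower number from compound 3 to compound 4 (0.15 log units; within the scatter)). No measured evidence gives a reason for this.

Open, on these data alone, is whether fluoro, an amine or a carboxylic acid on that aromatic ring would read like compound 2 or like compounds 3 and 4.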